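This account rests on a few compounds, and the source may have more. Where it says the series, first, only, none or still open, it means among the compounds named here.

Working notes on the chalcone series sharing the core of compound 1, `COc1ccc(/C=C/C(=O)c2ccc(OC)c3c2OC(C)(C)C=C3)c(F)c1`.

In a functional assay on SK-OV-3 cells (Homo sapiens) for antiproliferative activity, read by MTT assay, with a stated time of 24 h (a lower number here means a stronger inhibitor, a higher number a weaker inhibitor), compound 1 gives 4880 nM. Compound 2, `COc1ccc(C(=O)/C=C/c2cccc(F)c2)c2c1C=CC(C)(C)O2`, carries a 3-fluorophenyl in place of the 2-fluoro-4-methoxyphenyl; for compound 2 this assay reports only a limit, > 10000 nM, and it is one of the values at the limit of > 10000 nM in this assay, at which 1 of the 3 values shown sits. Compound 3, `COc1ccc(C(=O)/C=C/c2ccc(N(C)C)cc2)c2c1C=CC(C)(C)O2`, carries a 4-(dimethylamino)phenyl on the same chain carbon, and in this assay compound 3 gives 2750 nM. That leaves compound 3 with the lowest of the two numbers, with compound 1 nearest at a 1.8-fold lower number from compound 1 to compound 3 (0.25 log units; within the scatter), a gap that stays within the usual scatter; the step of an at least 3.6-fold lower number from compound 2 to compound 3 (0.56 log units; beyond the scatter) is the only one here beyond the scatter, and an at least 2.0-fold higher number from compound 1 to compound 2 (0.31 log units; beyond the scatter) is a limit-bound step.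

The next compound, compound 4, `COc1ccc(C(=O)/C=C/c2ccc(-n3ccnc3)cc2)c2c1C=CC(C)(C)O2`, differs from compound 3 by 1H-imidazol-1-yl in place of dimethylamino on an aromatic carbon. Among the measured compounds shown here, the steps that bear on it are those on the same aryl ring, which ranged from within the scatter to modest. Replacing dimethylamino by 1H-imidazol-1-yl is expected to give a small rise in number in this assay, about a 1.6-fold higher number from compound 3 to compound 4 (0.21 log units; within the scatter), without leaving the low-micromolar region. For compound 4 the estimated value in this assay is 4500 nM, within 1800 nM to 10000 nM.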

Compound 4, half-maximal inhibitory concentration: 7200 nM
Compound 4: the middle estimate sits 1.6-fold (0.20 log units) below what was measured; low and high end bracket the measured number.
By their numbers in this assay, from the lowest: compounds 3, 1 and 4 (each within the scatter of the next, the first and the last beyond it). At a limit, above all of these: compound 2.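

Among the compounds shown here, replacing dimethylamino by 1H-imidazol-1-yl is the first change here confined to one substituent on the aryl ring, on an aromatic carbon para to a large group, and in this assay it gives a 2.6-fold higher number from compound 3 to compound 4 (0.42 log units; beyond the scatter). The earlier steps shown here exchanged the whole aryl group, so they could not show that this single position responds to the group it carries, and this step does show that within the pair. In the same assay compound 4 still gives a measured number of 7200 nM with a five-membered aromatic ring on this carbon, but nothing measured here ties the step to that ring, to the larger group or to the change in hydrogen-bond acceptors.

Going by these compounds, how a saturated ring amine such as morpholine or a plain amino group would read on this aromatic carbon stays open, and these would help separate the effect of the ring from that of the nitrogen substitution. On these data alone, whether a carboxylic acid or a longer chain on the same carbon would follow the same direction also remains open.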